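Replacing Nitrophenyl with Dichlorophenyl in a Cytotoxicity Series

The compounds below may be only part of what the source reports. "The series", "measured", "known", "first", "only" and "open" are said of these compounds alone.

Of the compounds shown here, three built on one shared core have been tested in a functional assay on A549 cells (Homo sapiens) for cytotoxicity, read by MTT assay, with a stated time of 72 h; a lower number here means a stronger inhibitor, a higher number a weaker inhibitor. Compound 1 `CNC(=O)c1cc(Oc2ccc(C3=NNC(c4ccc([N+](=O)[O-])cc4)C3)cc2)ccn1` gives 19500 nM, which is the second highest of the three numbers. Compound 2 `CNC(=O)c1cc(Oc2ccc(C3=NNC(c4ccccc4)C3)cc2)ccn1` gives 8600 nM, and compound 3 `CNC(=O)c1cc(Oc2ccc(C3=NNC(c4ccc(Br)cc4)C3)cc2)ccn1` gives 21000 nM. Compound 1 and compound 3 lie within the scatter of each other, as a 1.1-fold higher number from compound 1 to compound 3 (0.03 log units; within the scatter) shows, whereas a 2.3-fold lower number from compound 1 to compound 2 (0.36 log units; beyond the scatter) and a 2.4-fold higher number from compound 2 to compound 3 (0.39 log units; beyond the scatter) show that the bare phenyl gives a modestly lower number than either the nitro or the bromo variant.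

Compound 4 `CNC(=O)c1cc(Oc2ccc(C3=NNC(c4cccc(Cl)c4Cl)C3)cc2)ccn1` has not yet been measured. It differs from compound 1 in one place: 2,3-dichlorophenyl in place of 4-nitrophenyl on a saturated ring carbon. The measured steps that bear on this change are the swaps of nitro for hydrogen and nitro for bromo. Since a halogen in place of nitro left the number essentially where it was, a dichlorophenyl is expected to resemble the bromo case rather than the bare phenyl. Compound 4 is therefore expected to show a 1.1-fold lower number from compound 1 to compound 4 (0.03 log units; within the scatter), a step not beyond the scatter. Compound 4 is estimated at 18000 nM, with a range from 7000 nM to 45000 nM.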

Compound 4, half-maximal inhibitory concentration: 12100 nM
Estimate against measurement, compound 4: 1.5-fold (0.17 log units) above; the range from low to high includes it.
By their numbers in this assay, from the lowest: compounds 2, 4, 1 and 3 (each within the scatter of the next, the first and the last beyond it).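

Within the data shown here, compound 4 is the first in this set to carry two substituents on the ring at this position, and in this assay it cannot be told apart from any of the others, with a 1.6-fold lower number from compound 1 to compound 4 (0.21 log units; within the scatter) and a 1.7-fold lower number from compound 3 to compound 4 (0.24 log units; within the scatter) as well as a 1.4-fold higher number from compound 2 to compound 4 (0.15 log units; within the scatter) all within the scatter. Compound 2 and compound 3 lie beyond the scatter of each other, yet compound 4 lies within the scatter of both, so the result groups the 2,3-dichlorophenyl neither with the bromo variant nor with the bare phenyl. Nothing shown here explains these small differences.

Going by these compounds, all four compounds keep a phenyl ring at this position, so the effect of a different group there, such as an amine, a carboxylic acid or a longer chain, remains open. Also open, on these data alone, is whether a single chlorine would give a number distinct from that of the two chlorines of compound 4.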